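A few compounds are considered here, and "the series" means these few. Any claim that something is new, unique, unknown or untested is made for them only; others in the source may bear on it.

Three compounds share one core and differ only in the aromatic ester group attached on an oxygen next to a carbonyl group. Compound 1 `COC(=O)c1c(F)cccc1OC(=O)COc1cc(O)c2c(=O)cc(-c3ccccc3)oc2c1` gives 319000 nM in an ADME assay on cells (T-cell, Mus musculus, strain BALB/c) for cytotoxicity, read by MTT assay, with a stated time of 48 h; a higher number here means that more compound is tolerated, a lower number that less compound is tolerated. Compound 2 `COC(=O)c1cc(O)ccc1OC(=O)COc1cc(O)c2c(=O)cc(-c3ccccc3)oc2c1` gives 263000 nM in this assay, and compound 3 `COC(=O)c1cccc(C)c1OC(=O)COc1cc(O)c2c(=O)cc(-c3ccccc3)oc2c1` gives 299000 nM in this assay. Compound 3 stands second highest of these three numbers, but every gap is small: the step of a 1.1-fold lower number from compound 1 to compound 3 (0.03 log units; within the scatter) and the step of a 1.1-fold higher number from compound 2 to compound 3 (0.06 log units; within the scatter) both stay within the scatter, as does the step of a 1.2-fold lower number from compound 1 to compound 2 (0.08 log units; within the scatter).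

Compound 4 `COC(=O)c1ccc(Cl)cc1OC(=O)COc1cc(O)c2c(=O)cc(-c3ccccc3)oc2c1` has not yet been measured in this assay. Its change from compound 3 is a group of 11 heavy atoms (8 carbon, 2 oxygen, 1 chlorine; one six-membered aromatic ring of carbon only) in place of a group of 11 heavy atoms (9 carbon, 2 oxygen; one six-membered aromatic ring of carbon only), on an oxygen next to a carbonyl group. All three measured steps bear on this question. Each of them also swaps one aromatic ester group for another at the same place, and none of them moved the number beyond the scatter. A chlorine-bearing ring has not been measured here, so the expectation rests only on those three swaps.

The expected step is therefore a 1.0-fold lower number from compound 3 to compound 4 (0.01 log units; within the scatter), no larger than the scatter, with no direction favoured. Compound 4 is estimated at 290000 nM in this assay, with a likely range from 190000 nM to 430000 nM.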

Compound 4, half-maximal cytotoxic concentration: 265000 nM
Estimate against measurement, compound 4: 1.1-fold (0.04 log units) above; measured number inside the range.
By their numbers in this assay, from the lowest: compounds 2, 4, 3 and 1 (each within the scatter of the next).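

Placing 5-chloro-2-(methoxycarbonyl)phenyl on an oxygen next to a carbonyl group brings a chlorine-bearing ring into the comparison, and in this assay this change gives a 1.1-fold lower number from compound 3 to compound 4 (0.05 log units; within the scatter), while the comparisons with the other two rings give a 1.0-fold higher number from compound 2 to compound 4 (0.00 log units; within the scatter) and a 1.2-fold lower number from compound 1 to compound 4 (0.08 log units; within the scatter). All three steps stay within the scatter, so across these four compounds a chlorine, a fluorine, a hydroxyl or a methyl on the aromatic ester group cannot be told apart by this read-out. No outside measurement is available to explain why these numbers stay so close together.

From the compounds shown here alone, all four aromatic ester groups keep the methoxycarbonyl group and differ only in one further substituent, so it remains open whether an amine, a carboxylic acid or a longer chain at this place would move the number beyond the scatter. Going by these compounds, it also remains open whether a change to the shared core, rather than to this ester group, would shift the number in this assay at all.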